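A Fluoro Substituent Tested on Two Weak Cores

The source may hold more compounds than are shown below. What is called first, only, known or untested is meant among the compounds shown, and "the series" means these compounds.

Compound 2 `Cc1ccc(S(=O)(=O)N(Cc2nc3ccccc3[nH]2)c2ccccc2)cc1` and compound 3 `COc1cc(N(Cc2nc3ccccc3[nH]2)C(=O)c2ccccc2)cc(OC)c1OC` are built on different cores; the difference between the two cores is not broken down here. In a functional assay on PC-3 cells (Homo sapiens) for inhibition, read by MTT assay, with a stated time of 48 h (a lower number here means a stronger inhibitor, a higher number a weaker inhibitor), compound 2 gives only a limit, > 50000 nM. Compound 3 also gives only a limit in this assay, > 50000 nM. Compound 1 `Cc1ccc(S(=O)(=O)N(Cc2nc3ccccc3[nH]2)c2ccc(F)cc2)cc1` differs from compound 2 by fluoro in place of hydrogen on an aromatic carbon. In this assay compound 1 gives 45000 nM, a step of an at least 1.1-fold lower number from compound 2 to compound 1 (0.04 log units; that floor lies within the scatter). Compound 4 `COc1cc(N(Cc2nc3ccccc3[nH]2)C(=O)c2ccc(F)cc2)cc(OC)c1OC` is not yet measured and carries the same change relative to compound 3, (fluoro in place of hydrogen on an aromatic carbon), at the same kind of place on the ring. Because (the limit of > 50000 nM in this assay, at which 2 of the 3 values shown sit), the measured example of this change offers no sign that it moves the number far, and compound 4 is expected to stay close to its parent. For compound 4 the expected step is an at least 1.0-fold lower number from compound 3 to compound 4 (0.01 log units; that floor lies within the scatter). Compound 4 is therefore estimated at 48000 nM in this assay, between 20000 nM and 100000 nM, with a fair chance that only a limit is reported.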

Compound 4, half-maximal inhibitory concentration: 21900 nM
Compound 4: the middle estimate sits 2.2-fold (0.34 log units) above what was measured; the measured number falls inside the stated range.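

In this assay, fluoro in place of hydrogen on an aromatic carbon gives an at least 2.2-fold lower number from compound 3 to compound 4 (0.35 log units; beyond the scatter), so on this second core the change produces a step that stands clear of the usual scatter. Set beside the first example, the two steps compare as follows: the same change on two cores in this assay, an at least 1.1-fold lower number (0.04 log units; that floor lies within the scatter) from compound 2 to compound 1 and an at least 2.2-fold lower number (0.35 log units; beyond the scatter) from compound 3 to compound 4; the limit leaves it open whether they differ The pair therefore shows that the change can be carried to the core of compound 3 and still give a measurable number, but it does not show that the core alters the size of the step, since neither parent has a number of its own: the limit of > 50000 nM in this assay, at which 2 of the 4 values shown sit.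

The compounds shown leave open whether a chloro, a methoxy, an amine or a carboxylic acid in the place of the fluoro would move the number further on either core. As far as these compounds go, it also remains open whether the same step would appear on a third core, and whether any such change could bring these weak compounds to a much lower number.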